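The source may report more compounds than this note shows. Statements on the series, on what has been measured and on what is new or still open speak of the compounds shown alone.

Values in a functional assay on Huh-7 cells (Homo sapiens) for inhibition, read by CCK-8 assay, with a stated time of 72 h (on this read-out higher numbers stand for weaker inhibition and lower numbers for stronger inhibition), for the series

compound 1 `O=C(/C=C/c1cccnc1)NCCCCCc1cccc(S(=O)(=O)Nc2ccccc2)c1` gives 41.1 nM
compound 2 `O=C(/C=C/c1cccnc1)NCCCCCCc1cccc(S(=O)(=O)Nc2ccccc2)c1` gives 2.82 nM
compound 3 `Cc1ccccc1NS(=O)(=O)c1cccc(CCCCCCNC(=O)/C=C/c2cccnc2)c1` gives 0.525 nM

Compound 2 holds the second highest of the three numbers in this assay, with compound 1 higher and compound 3 lower. The next compound is compound 4 `O=C(/C=C/c1cccnc1)NCCCCCCc1cccc(S(=O)(=O)Nc2ccc(Oc3ccccc3)cc2)c1`, which differs from compound 2 by phenoxy in place of hydrogen on an aromatic carbon in the form of phenoxy in place of hydrogen on an aromatic carbon, para to a large group. Among the compounds with values here, only one measured step bears on this change, a 5.4-fold lower number from compound 2 to compound 3 (0.73 log units; beyond the scatter), which is modest and beyond the scatter and also replaces hydrogen on an aromatic carbon. That step involves methyl, a far smaller group than phenoxy, and it sits at a different place, so it is weak guidance on direction. Within the data shown here, no measured compound carries phenoxy, and no step beyond the scatter is therefore expected in this assay, though a wide range is kept in either direction. The expected change is a 1.4-fold lower number from compound 2 to compound 4 (0.15 log units; within the scatter) as the estimate stands. For compound 4 the estimated value is 2 nM within an expected range of 0.3 nM to 15 nM in this read-out.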

Compound 4, half-maximal inhibitory concentration: 32.7 nM
Estimate against measurement, compound 4: 16-fold (1.21 log units) below; measured number outside the range, above it.
By their numbers in this assay, from the lowest: compound 3; then compound 2; then compounds 4 and 1 (each within the scatter of the next).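

In this assay, phenoxy in place of hydrogen on an aromatic carbon, para to a large group, gives a 12-fold higher number from compound 2 to compound 4 (1.06 log units; beyond the scatter), so this position does not take this group without a large loss of inhibition. Within the data shown here, the only earlier step of this kind, a 5.4-fold lower number from compound 2 to compound 3 (0.73 log units; beyond the scatter), ran the other way with methyl, so replacing hydrogen on an aromatic carbon has no single direction, and the two steps cannot separate the effect of the group from that of its place. No measured information here accounts for the size of the phenoxy step.

As far as these compounds go, it remains open whether a methoxy or a chlorine at this same place would stay close to compound 2 at 2.82 nM. A methyl at this place would show whether the gain seen with compound 3 carries over to it.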